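The source may hold more compounds than are shown below. What is called first, only, known or untested is meant among the compounds shown, and "the series" means these compounds.

For the measured compounds named here, compound 1 `C=C1CN(C)N(c2ccc(Cl)cc2)C1=O` is one of two compounds with a number so far. In a functional assay on HL-60 cells (Homo sapiens) for inhibition, read by MTT assay, with a stated time of 48 h (a lower number here means a stronger inhibitor, a higher number a weaker inhibitor), compound 1 gives 38100 nM, the highest of the two numbers, so it is the weaker inhibitor of the pair. The other measured compound, compound 2 `C=C1C(=O)N(c2ccccc2)N(c2ccccc2)C1C`, gives 5850 nM in this assay; the gap between the two lies beyond the usual scatter, and the two structures differ in more than one place, so no single change can be read from them.

Compound 3 `C=C1CN(C)N(c2ccccc2)C1=O` has not yet been measured. It differs from compound 1 in one place: hydrogen in place of chloro on an aromatic carbon. Going by the values given here, no measured pair shows this exchange, so its effect in this assay is unknown; a small step, if any, is expected, not beyond the scatter.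

Compound 3 is therefore expected to give about 45000 nM in this assay, within 15000 nM to 130000 nM. The step of a 1.2-fold higher number from compound 1 to compound 3 (0.07 log units; within the scatter) is an estimate only.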

Compound 3, half-maximal inhibitory concentration: 45700 nM
Beside the measured number, compound 3's estimate is 1.0-fold (0.01 log units) below it, within the range that was stated.
By their numbers in this assay, from the lowest: compound 2; then compounds 1 and 3 (each within the scatter of the next).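

Hydrogen in place of chloro on the aromatic carbon, para to a group of 8 heavy atoms, gives a 1.2-fold higher number from compound 1 to compound 3 (0.08 log units; within the scatter) in this assay and is the first exchange at this position that can be read directly. Compound 1 and compound 3 therefore cannot be told apart in this assay, and the chloro group makes no difference here that can be distinguished from the scatter. No measurement shown offers an explanation for this result.

On these data alone, whether a different group at this position, such as a methoxy group, an amine or a carboxylic acid, would give a step beyond the scatter remains open. Compound 2 differs from compound 1 and compound 3 in more than one place, so what separates its number from theirs cannot be traced to any single change.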